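Thiazole amides and ethers: cytotoxicity notes

A few compounds are considered here, and "the series" means these few. Any claim that something is new, unique, unknown or untested is made for them only; others in the source may bear on it.

Measured so far in an ADME assay on HepG2 2.2.15 cells (Homo sapiens) for cytotoxicity; on this read-out higher numbers stand for lower toxicity in this test and lower numbers for higher toxicity in this test:
- compound 1 `Cc1ccc(C(=O)Nc2ncc(Cc3ccc(F)cc3)s2)cc1` gives "not toxic" (no number reported)
- compound 2 `Cc1cc(Br)cc(OC(c2ccc(Cl)cc2)c2cnc(NC(=O)OC(C)(C)C)s2)c1` gives > 50000 nM
- compound 3 `Clc1ccc(C(Oc2ccc3cc(Br)ccc3c2)c2cnc(NCC3CCCCC3)s2)cc1` gives "not toxic" (no number reported)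

Compound 3 `Clc1ccc(C(Oc2ccc3cc(Br)ccc3c2)c2cnc(NCC3CCCCC3)s2)cc1` has no single number in this assay; it is reported only as not toxic. Compound 1 stands the same way, without a number. Compound 2 is reported as a limit of the assay, > 50000 nM, and not as a number; (the limit of > 50000 nM in this assay, at which 1 of the 3 values shown sits). So no measured pair differs in one place and no step size is on record.

Compound 4 `Cc1noc(C)c1C(=O)Nc1ncc(C(Oc2ccc3cc(Br)ccc3c2)c2ccc(Cl)cc2)s1` is not yet measured in this assay. It differs from compound 3 as follows: (3,5-dimethyl-1,2-oxazol-4-yl)carbonyl in place of cyclohexylmethyl on a nitrogen on an aromatic ring. Among the compounds with values here, since nothing so far has given a number, no step between compound 3 and compound 4 can be sized from measured pairs; the expectation is that the change stays within the scatter, with no clear direction, and that compound 4 also comes back at or beyond the limit in this assay. The estimate for compound 4 is 60000 nM, in the range 20000 nM to 200000 nM, most likely reported as a limit rather than a number.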

Compound 4, half-maximal cytotoxic concentration: "not toxic" (no number reported)
Nothing numeric was reported for compound 4, and the estimate cannot be compared.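

Compound 3 and compound 4 are both reported only as not toxic in this assay, so no step can be read between them. The compounds shown leave open at what concentration any of them would become toxic, with compound 2 reported only at a limit: the limit of > 50000 nM in this assay, at which 1 of the 4 values shown sits.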